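The compounds below may be only part of what the source reports. "The series", "measured", "known", "first", "only" and "open" are said of these compounds alone.

Compound 1 `CC[C@@H]1C(=O)N(C)c2cnc(Nc3ccc(S(=O)(=O)NCCO)cc3)nc2N1C1CCCC1`: 278 nM
Compound 2 `CC[C@@H]1C(=O)N(C)c2cnc(Nc3ccc(S(N)(=O)=O)cc3)nc2N1C1CCCC1`: 1300 nM

In a functional assay on Huh-7 cells (Homo sapiens) for antiproliferative activity, read by CCK-8 assay, with a stated time of 72 h (on this read-out lower numbers stand for stronger inhibition of growth and higher numbers for weaker inhibition of growth), compound 2 stands highest of the two numbers measured; its nearest neighbour is compound 1, reached by a 4.7-fold higher number from compound 1 to compound 2 (0.67 log units; beyond the scatter). Compound 3 `CC[C@@H]1C(=O)N(C)c2cnc(Nc3ccc(S(=O)(=O)NCC(C)C)cc3)nc2N1C1CCCC1` differs from compound 2 by isobutyl in place of hydrogen on a sulfonamide nitrogen, a substituent entering on the sulfonamide nitrogen where compound 1 also carries one. Among the measured compounds shown here, the one step that bears on this, a 4.7-fold higher number from compound 1 to compound 2 (0.67 log units; beyond the scatter), went beyond the scatter when that nitrogen lost its group, so regaining a group there is expected to lower the number in this assay, though with an isobutyl rather than a 2-hydroxyethyl the size is uncertain. This change is therefore expected to give a 2.9-fold lower number from compound 2 to compound 3 (0.46 log units; beyond the scatter). Compound 3 is expected at 450 nM, within 150 nM to 1400 nM.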

Compound 3, concentration for 50% growth inhibition: 411 nM
Estimate against measurement, compound 3: 1.1-fold (0.04 log units) above; measured number inside the range.
By their numbers in this assay, from the lowest: compounds 1 and 3 (each within the scatter of the next); then compound 2.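

In this assay an isobutyl on the sulfonamide nitrogen gives a 3.2-fold lower number from compound 2 to compound 3 (0.50 log units; beyond the scatter) and so shows that a chain of carbon alone, with no hydrogen-bond donor or acceptor, also lowers the number from the unsubstituted sulfonamide. Against the 2-hydroxyethyl chain the change gives a 1.5-fold higher number from compound 1 to compound 3 (0.17 log units; within the scatter) and so, in this pair, the hydroxyl is not needed to keep the lower number. Nothing measured here explains the effect of either chain. As far as these compounds go, whether an amine or a carboxylic acid on this chain, or a longer chain, would do the same stays open.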